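The source may hold more compounds than are shown below. What is called first, only, known or untested is meant among the compounds shown, and "the series" means these compounds.

Working notes on the series in a functional assay on PC-3 cells (Homo sapiens) for cytotoxicity, read by WST assay, with a stated time of 72 h; on this read-out higher numbers stand for weaker inhibition and lower numbers for stronger inhibition. Compound 1 `O=C1Nc2c(ccc(F)c2F)C1(c1ccccc1)c1ccc(O)cc1` gives 8.9 nM, compound 2 `Cc1ccc(C2(c3ccc(O)cc3)C(=O)Nc3c2ccc(F)c3F)cc1` gives 0.8 nM, and compound 3 `CCOc1ccc(C2(c3ccc(O)cc3)C(=O)Nc3c2ccc(F)c3F)cc1` gives 24 nM. Compound 2 has the lowest number of the three, and its gaps to both of the others lie beyond the scatter.

The next compound to be read is compound 4 `CCCOc1ccc(C2(c3ccc(O)cc3)C(=O)Nc3c2ccc(F)c3F)cc1`, with propoxy in place of methyl on an aromatic carbon, para to a large group: propoxy in place of methyl on an aromatic carbon.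

For the measured compounds named here, the closest precedent is the exchange of methyl for ethoxy, a 30-fold higher number from compound 2 to compound 3 (1.48 log units; beyond the scatter), a large step. Two steps from the hydrogen parent frame it: methyl gives an 11-fold lower number from compound 1 to compound 2 (1.05 log units; beyond the scatter), a large step, while ethoxy gives a 2.7-fold higher number from compound 1 to compound 3 (0.43 log units; beyond the scatter), a modest one. Going by the values given here, no measured compound shows what the longer propoxy chain adds beyond ethoxy. A large step to a higher number is therefore expected in this assay, close in size to the ethoxy step. The estimated step is a 38-fold higher number from compound 2 to compound 4 (1.57 log units; beyond the scatter). The expected value for compound 4 is 30 nM. The estimated range for compound 4 runs from 10 nM to 90 nM.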

Compound 4, half-maximal inhibitory concentration: > 1000 nM
Compound 4: no number, only a limit; the forecaster's own chance of this, stated with the estimate: 1%; at least 33-fold (1.52 log units) between middle value and limit.
By their numbers in this assay, from the lowest: compound 2; then compound 1; then compound 3. At a limit, above all of these: compound 4.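

In this assay, compound 4 gives a limit and not a number: the limit of > 1000 nM in this assay, at which 1 of the 4 values shown sits. At this position, para to a large group, the propoxy exchange gives an at least 1200-fold higher number from compound 2 to compound 4 (3.09 log units; beyond the scatter), and against the hydrogen parent it gives an at least 110-fold higher number from compound 1 to compound 4 (2.05 log units; beyond the scatter), so this alkoxy change is not confined to the modest shift seen with ethoxy. The single extension of the chain, methyl in place of hydrogen on a saturated chain carbon, two bonds along the chain from an oxygen on an aromatic ring, gives an at least 41-fold higher number from compound 3 to compound 4 (1.61 log units; beyond the scatter), which shows that the read-out at this position is highly sensitive to alkoxy chain length.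

From the compounds shown here alone, with a limit at one end, the true size of all three steps stays open. Also open, going by these compounds, is how methoxy, a longer butoxy chain or an amine on the propoxy chain would read here.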